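A few compounds are considered here, and "the series" means these few. Any claim that something is new, unique, unknown or untested is made for them only; others in the source may bear on it.

Compound 1, `c1ccc(C2CCCCN2C2CCN(CCCc3c[nH]c4ccc(-n5cnnc5)cc34)CC2)cc1`, gives 410 nM.
Compound 2, `OC[C@H](NC1CCN(CCCc2c[nH]c3ccc(-n4ccnc4)cc23)CC1)c1ccccc1`, gives 100 nM.
Compound 3, `CC(=O)Nc1ccc([C@H](C)NCC2CCN(CCCc3c[nH]c4ccc(-n5cnnc5)cc34)CC2)cc1`, gives 9.3 nM.

These three values come from an assay on CHO cells for displacement of a labelled ligand from 5-hydroxytryptamine receptor 1B (Homo sapiens); on this read-out lower numbers stand for stronger inhibition and higher numbers for weaker inhibition. Within this small set compound 2 stands second highest of the three numbers. Its nearest neighbour is compound 1, whose number is higher and lies beyond the scatter; compound 3 is the furthest, with a number lower than that of compound 2 by a gap that is also beyond the scatter. No two of the measured compounds differ in only one place, so no measured step can be read directly from them.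

Compound 4, `OC[C@H](NC1CCN(CCCc2c[nH]c3ccc(Cn4cncn4)cc23)CC1)c1ccccc1`, has not yet been measured. It differs from compound 2 in one place: (1H-1,2,4-triazol-1-yl)methyl in place of 1H-imidazol-1-yl on an aromatic carbon. Among the measured compounds shown here, no measured pair shows this kind of exchange. The size of the step in this assay can therefore only be guessed. Little change is expected, and if anything a small weakening, most likely within or close to the scatter. On that basis compound 4 is estimated at 150 nM, with a range from 40 nM to 600 nM, which would mean a step of a 1.5-fold higher number from compound 2 to compound 4 (0.18 log units; within the scatter).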

Compound 4, half-maximal inhibitory concentration: 1300 nM
Compound 4: the middle estimate sits 8.7-fold (0.94 log units) below what was measured; measured number above the stated range.
By their numbers in this assay, from the lowest: compound 3; then compound 2; then compound 1; then compound 4.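

In this assay, the exchange of 1H-imidazol-1-yl for (1H-1,2,4-triazol-1-yl)methyl on this aromatic carbon gives a 13-fold higher number from compound 2 to compound 4 (1.11 log units; beyond the scatter), a large weakening of inhibition that lies beyond the scatter. The earlier compounds shown here differ from one another in more than one place, so they could not show that a change at this position alone can shift the number so strongly. Nothing available here explains the loss.

The exchange alters two things at once, adding a methyl link and moving from 2 to 3 hetero atoms in the ring, and the compounds shown leave open how much each contributes. A (1H-imidazol-1-yl)methyl group or a directly attached 1H-1,2,4-triazol-1-yl group at this position would help separate the two, while a primary amide would test a different kind of group.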